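The source may report more compounds than this note shows. Statements on the series, on what has been measured and on what is new or still open speak of the compounds shown alone.

Measured compounds:
- compound 1, `Oc1ccc(-c2nc3ncccn3c2NC2CCCCC2)cc1`: > 100000 nM in a toxicity assay on A549 cells (Homo sapiens) for cytotoxicity, read by luminescence and CellTiter-Glo, with a stated time of 48 h; on this read-out higher numbers stand for lower toxicity in this test and lower numbers for higher toxicity in this test
- compound 2, `COc1ccccc1-c1nc2ncccn2c1NC1CCCCC1`: > 100000 nM in this assay

In this assay compound 1 reaches only the limit of the test, > 100000 nM. In the same test compound 2 likewise reaches only a limit, > 100000 nM. Going by the values given here, the one measured step, a step that the two limits leave unreadable from compound 1 to compound 2, therefore cannot be read, and the limit of > 100000 nM in this assay, at which 2 of the 2 values shown sit, describes where both values sit. Compound 2 thus stands at the top of the range the test can report, alongside compound 1, with no ordering between them.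

Compound 3, `COc1ccccc1-c1nc2ncccn2c1N(C(C)=O)C1CCCCC1`, differs from compound 2 by acetyl in place of hydrogen on a nitrogen on an aromatic ring. Among the compounds with values here, no measured step touches this part of the molecule, and the one step that exists gives no size. With both measured compounds sitting at the limit, the expected step that the limit leaves unreadable from compound 2 to compound 3 for compound 3 is none beyond the scatter. Compound 3 is therefore estimated at 150000 nM in this test, with a range from 40000 nM to 500000 nM, and most likely again only a limit.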

Compound 3, half-maximal cytotoxic concentration: > 100000 nM
Compound 3 was reported as a limit; the forecaster's own chance of this, stated with the estimate: 75%; the middle value lies beyond the limit too.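

Compound 3 gives only a limit in this assay, > 100000 nM. Going by these compounds alone, the step from compound 2 to compound 3 therefore cannot be read, and compounds 1, 2 and 3 yield no new step: the limit of > 100000 nM in this assay, at which 3 of the 3 values shown sit. The compounds shown leave open whether any change to the shared core brings a value within the range this test can report.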